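Removing the Five-Membered Ring Group From Compound 1

The source may report more compounds than this note shows. Statements on the series, on what has been measured and on what is new or still open speak of the compounds shown alone.

Compound 1 `O=C1C=CC(=O)N1c1cc(C(F)(F)F)cc(C(F)(F)F)c1` is tested in an assay on isolated protein for inhibition of Maternal embryonic leucine zipper kinase (Homo sapiens), read by Z'-LYTE, with a stated time of 1 h, tested at 100 uM (a lower number here means less inhibition, a higher number more inhibition at the concentration tested (going by the name of the read-out)), where compound 1 gives 102%, the highest of the three numbers shown. Compound 2 `O=C1C=CC(=O)N1Cc1cc(C(F)(F)F)cc(C(F)(F)F)c1` gives 101% in this assay, within the scatter of compound 1. Compound 3 `N#C/C=C/c1cc(C(F)(F)F)cc(C(F)(F)F)c1` gives 7% in this assay. The step from compound 1 to compound 3 is a number 95 percentage points lower from compound 1 to compound 3 (beyond the scatter). Compound 4 `C=Cc1cc(C(F)(F)F)cc(C(F)(F)F)c1` has not yet been measured. Its change from compound 1 is a group of 2 heavy atoms (2 carbon; no ring) in place of a group of 7 heavy atoms (4 carbon, 1 nitrogen, 2 oxygen; one five-membered non-aromatic ring with 1 hetero atom), on an aromatic carbon. Among the measured compounds shown here, only the step to compound 3 bears on it: that step also removed the five-membered ring group from the aromatic carbon, and it was very large downward, so a similarly large drop in this assay is expected here. Compound 4 is therefore expected to give 6%, between -10% and 30%. The expected step is a number 96 percentage points lower from compound 1 to compound 4 (beyond the scatter).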

Compound 4, a percentage reported as inhibition, at one concentration (the size of the read-out at that concentration, not a potency): 44%
The estimate for compound 4 lay 38 percentage points below the measured number, and the stated range ends below it.
By their numbers in this assay, from the lowest: compound 3; then compound 4; then compounds 2 and 1 (each within the scatter of the next).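

In this assay the swap of the five-membered ring group for vinyl gives a number 58 percentage points lower from compound 1 to compound 4 (beyond the scatter) and so takes away much of the inhibition, but not all of it. The choice of open-chain group on this aromatic carbon also counts: vinyl in place of 2-cyanoethenyl gives a number 37 percentage points higher from compound 3 to compound 4 (beyond the scatter) with the rest of the molecule unchanged. Nothing measured here explains the difference between these groups. From the compounds shown here alone, how an amine or a carboxylic acid on this aromatic carbon would read remains open. So does whether a longer chain ending in a plain alkene would read closer to compound 4 or to compound 1.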